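This account rests on a few compounds, and the source may have more. Where it says the series, first, only, none or still open, it means among the compounds named here.

Going by the values given here, in a functional assay on HepG2 cells (Homo sapiens) for cytotoxicity, read by MTT assay, with a stated time of 72 h (on this read-out higher numbers stand for weaker inhibition and lower numbers for stronger inhibition), compound 1 `CN1[C@@H]2c3[nH]c4ccccc4c3C[C@H]1[C@H](C#N)N1[C@@H](CN3C(=O)c4ccccc4C3=O)c3[nH]c4ccccc4c3C[C@@H]21` gives 20 nM, the lowest of the three numbers measured so far. Compound 2 `CN1[C@@H]2c3[nH]c4ccccc4c3C[C@H]1[C@H](C#N)N1[C@@H](CNC(=O)c3ccc4ccccc4n3)c3[nH]c4ccccc4c3C[C@@H]21` gives 110 nM, and compound 3 `CN1[C@@H]2c3[nH]c4ccccc4c3C[C@H]1[C@H](C#N)N1[C@@H](CNC(=O)c3cc4ccccc4s3)c3[nH]c4ccccc4c3C[C@@H]21` gives 300 nM. Compound 4 `CN1[C@@H]2c3[nH]c4ccccc4c3C[C@H]1[C@H](C#N)N1[C@@H](CNC(=O)c3cc4ccccc4o3)c3[nH]c4ccccc4c3C[C@@H]21` has not yet been measured in this assay; against compound 1 it carries a group of 12 heavy atoms (9 carbon, 1 nitrogen, 2 oxygen; one five-membered aromatic ring with 1 hetero atom, one six-membered aromatic ring of carbon only) in place of a group of 11 heavy atoms (8 carbon, 1 nitrogen, 2 oxygen; one five-membered non-aromatic ring with 1 hetero atom, one six-membered aromatic ring of carbon only), on a saturated chain carbon bound to a saturated ring carbon. Among the compounds with values here, two measured steps bear on this change. The closer one is a 15-fold higher number from compound 1 to compound 3 (1.18 log units; beyond the scatter), where the same group leaves and a group with 1-benzothiophen-2-yl on the carbonyl carbon enters at the same place. The other is a 2.7-fold higher number from compound 2 to compound 3 (0.44 log units; beyond the scatter), which shows that swapping one two-ring aromatic group for another on that carbonyl carbon moves the number only modestly. Compound 4 is therefore expected to sit well above compound 1 and close to compounds 2 and 3, with a large step of a 10-fold higher number from compound 1 to compound 4 (1.00 log units; beyond the scatter). The estimate for compound 4 in this assay is 200 nM, expected to fall between 70 nM and 600 nM.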

Compound 4, half-maximal inhibitory concentration: 280 nM
For compound 4 the middle estimate is 1.4-fold (0.15 log units) below the measured one, and the stated range covers the measured number.
By their numbers in this assay, from the lowest: compound 1; then compound 2; then compounds 4 and 3 (each within the scatter of the next).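

In this assay the change from the group of compound 1 to ((1-benzofuran-2-yl)carbonyl)amino gives a 14-fold higher number from compound 1 to compound 4 (1.15 log units; beyond the scatter) and so shows that the large step seen with the benzothiophene compound is not specific to that one group. Going by these compounds alone, the exchange of 1-benzothiophen-2-yl for 1-benzofuran-2-yl on the carbonyl carbon gives a 1.1-fold lower number from compound 3 to compound 4 (0.03 log units; within the scatter) and leaves the number unchanged within the scatter, a comparison the earlier compounds could not offer. Quinolin-2-yl remains modestly apart, with a 2.5-fold higher number from compound 2 to compound 4 (0.41 log units; beyond the scatter) in the same direction as a 2.7-fold higher number from compound 2 to compound 3 (0.44 log units; beyond the scatter) in the earlier pair.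

No evidence is available on what causes these steps. As far as these compounds go, it remains open whether the amide hydrogen, which compound 4 has and compound 1 lacks, has any part in the large step, and how a free primary amine or an N-methyl amide would read at this place.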